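Triazole diol in place of the piperazine ethyl group

A few compounds are considered here, and "the series" means these few. Any claim that something is new, unique, unknown or untested is made for them only; others in the source may bear on it.

Measured in a functional assay on HCT-116 cells (Homo sapiens) for cytotoxicity, read by MTT assay, with a stated time of 72 h; a lower number here means a stronger inhibitor, a higher number a weaker inhibitor:
- compound 1 `O=C1c2c[n+]([O-])c3ccccc3c2C(=O)c2c1c1ccccc1n2Cc1cn(C[C@H](O)CO)nn1`: 400 nM
- compound 2 `CN1CCN(CCCCn2c3c(c4ccccc42)C(=O)c2c[n+]([O-])c4ccccc4c2C3=O)CC1`: 10 nM
- compound 3 `CN1CCN(CCCn2c3c(c4ccccc42)C(=O)c2c[n+]([O-])c4ccccc4c2C3=O)CC1`: 560 nM

Compound 3 gives the highest of the three numbers at 560 nM, yet it lies within the scatter of compound 1. The gap on the other side is large: a 56-fold higher number from compound 2 to compound 3 (1.75 log units; beyond the scatter).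

Compound 4 `O=C1c2c[n+]([O-])c3ccccc3c2C(=O)c2c1c1ccccc1n2Cc1cn(C[C@@H](O)CO)nn1` is reached from compound 3 by 1-(2,3-dihydroxypropyl)-1H-1,2,3-triazol-4-yl in place of 2-(4-methylpiperazin-1-yl)ethyl on a saturated chain carbon bound to an aromatic nitrogen. The closest evidence is a 1.4-fold higher number from compound 1 to compound 3 (0.15 log units; within the scatter), which is the same exchange of groups run the other way. The large step of a 40-fold lower number from compound 1 to compound 2 (1.60 log units; beyond the scatter) has a different group entering, 3-(4-methylpiperazin-1-yl)propyl, so it bears on this change only indirectly. Going by the values given here, no measured step tests the defined stereocentre of the entering group, which leaves some extra uncertainty. No change beyond the scatter is therefore expected in this assay. The expected step is a 1.4-fold lower number from compound 3 to compound 4 (0.15 log units; within the scatter). For compound 4 the estimated value is 400 nM, with an expected range of 150 nM to 1100 nM.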

Compound 4, half-maximal inhibitory concentration: 190 nM
Compound 4: middle estimate off by 2.1-fold (0.32 log units), on the high side; the measured number falls inside the stated range.
By their numbers in this assay, from the lowest: compound 2; then compound 4; then compounds 1 and 3 (each within the scatter of the next).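

The stereocentre of the 1-(2,3-dihydroxypropyl)-1H-1,2,3-triazol-4-yl group now has a direct test in this assay, and its effect is modest but beyond the scatter: a 2.1-fold lower number from compound 1 to compound 4 (0.32 log units; beyond the scatter). With the centre drawn R, the exchange for 2-(4-methylpiperazin-1-yl)ethyl also gives a step beyond the scatter, a 2.9-fold lower number from compound 3 to compound 4 (0.47 log units; beyond the scatter), so the earlier reading of no change holds only for the S form, and the new step can be set on configuration alone because of this: the fact that compounds 1 and 4 differ only in the configuration as drawn. Even so, the R form stays far from the 3-(4-methylpiperazin-1-yl)propyl group: a 19-fold higher number from compound 2 to compound 4 (1.28 log units; beyond the scatter).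

On these data alone, whether the preference for R survives with a longer chain or a primary amine in place of the 2,3-dihydroxypropyl group remains open. Also open, as far as these compounds go, is how the triazole would read carrying a 4-methylpiperazin-1-yl group.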